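Hydroxamic amide on the cyclopropane: compound 4

The source may hold more compounds than are shown below. What is called first, only, known or untested is meant among the compounds shown, and "the series" means these compounds.

Compound 1 `Cc1nc(-c2ccc(C(F)(F)F)cc2)sc1CNc1ccc(C(=O)O)cc1` carries a carboxy group on the aromatic carbon; in a functional assay on CHO cells for agonist activity at Free fatty acid receptor 1 (Homo sapiens) (on this read-out higher numbers stand for an effect only at larger amounts of compound and lower numbers for an effect already at smaller amounts), compound 1 gives only a limit, < 10000 nM, and the limit of < 10000 nM in this assay, at which 1 of the 3 values shown sits, leaves its steps to the other compounds unreadable. Compound 2 `Cc1nc(-c2ccc(C(F)(F)F)cc2)sc1CNc1ccc([C@H]2C[C@@H]2C(N)=O)cc1` carries the 2-carbamoylcyclopropyl group in its place, and in this assay compound 2 gives 4.47 nM. Compound 3 `Cc1nc(-c2ccc(C(F)(F)F)cc2)sc1CNc1ccc([C@H]2C[C@@H]2C(=O)N(C)C)cc1` carries the 2-(dimethylcarbamoyl)cyclopropyl group; in this assay compound 3 gives 66.1 nM, the highest of the two numbers shown, and the step of a 15-fold higher number from compound 2 to compound 3 (1.17 log units; beyond the scatter) is large and beyond the scatter. Compound 4 `Cc1nc(-c2ccc(C(F)(F)F)cc2)sc1CNc1ccc([C@H]2C[C@@H]2C(=O)NO)cc1` differs from compound 3 in one place: hydroxyamino in place of dimethylamino on a carbonyl carbon. Among the measured compounds shown here, the only measured step that bears on this change is a 15-fold higher number from compound 2 to compound 3 (1.17 log units; beyond the scatter), in which dimethylamino entered for amino on the carbonyl carbon; in compound 4 the hydroxyamino group again brings hydrogen-bond donors to that carbonyl. The expected step is a lower number, a 6.6-fold lower number from compound 3 to compound 4 (0.82 log units; beyond the scatter), in the direction opposite to that measured step. For compound 4 in this assay the expected value is 10 nM, within the range 3 nM to 40 nM.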

Compound 4, half-maximal effective concentration: 6.92 nM
Compound 4: middle estimate off by 1.4-fold (0.16 log units), on the high side; measured number inside the range.
By their numbers in this assay, from the lowest: compounds 2 and 4 (each within the scatter of the next); then compound 3.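

In this assay, hydroxyamino on this carbonyl carbon gives a 9.6-fold lower number from compound 3 to compound 4 (0.98 log units; beyond the scatter), so the higher number seen with dimethylamino does not follow from every replacement of amino at this place. Hydroxy in place of hydrogen on the amide-type nitrogen gives a 1.5-fold higher number from compound 2 to compound 4 (0.19 log units; within the scatter), which shows that a substituent on that nitrogen need not carry the number away from that of compound 2; of the three amides, only compound 3 stands apart. The steps from compound 1 to the other compounds cannot be read, compound 1 being a limit: the limit of < 10000 nM in this assay, at which 1 of the 4 values shown sits.

Open, from the compounds shown here alone, is whether methylamino or methoxyamino on this carbonyl carbon would read with compounds 2 and 4 or with compound 3, which would show whether the hydrogen left on the nitrogen or the number of groups there goes with the step. Also open, going by these compounds, is how a carboxylic acid in place of the amide on the cyclopropyl group would read.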